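The source may report more compounds than this note shows. Statements on the series, on what has been measured and on what is new or still open speak of the compounds shown alone.

Among the measured compounds shown here, compound 3, `CCCC(Nc1cncc(-c2ccc(O)c(OC)c2)n1)c1ccc(Cl)cc1`, gives 20000 nM in a functional assay on PC-3 cells (Homo sapiens) for cytotoxicity, read by MTT assay, with a stated time of 72 h (on this read-out lower numbers stand for stronger inhibition and higher numbers for weaker inhibition), the highest of the three numbers measured so far. Compound 2, `CCCC(Nc1cncc(-c2ccc(O)c(OC)c2)n1)c1ccc(OC)cc1`, gives 3000 nM in this assay, and compound 1, `CCC[C@H](Nc1cncc(-c2ccc(O)c(OC)c2)n1)c1ccccc1`, gives 160 nM. The one single-point step among these three runs a 6.7-fold higher number from compound 2 to compound 3 (0.82 log units; beyond the scatter), so swapping one group on the phenyl ring of this side chain can move the number substantially.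

Compound 4, `CCCC(Nc1cncc(-c2ccc(O)c(OC)c2)n1)c1cccc(F)c1`, is the next step from compound 3: 3-fluorophenyl in place of 4-chlorophenyl on a saturated chain carbon bound to a nitrogen on an aromatic ring and a saturated chain carbon. For the measured compounds named here, no measured pair shows a halogen exchanged for another halogen or a group moved to a different ring position, so the expectation rests only loosely on what is known. The step from compound 2 to compound 3 shows that this ring is sensitive to what sits on it, and compound 1, which carries an unsubstituted phenyl at this place, gives the lowest number of the three, which suggests that a smaller substituent may sit closer to that end than compound 3 does. A modest move toward a lower number is therefore expected, a 4.0-fold lower number from compound 3 to compound 4 (0.60 log units; beyond the scatter), though with wide uncertainty. The estimate for compound 4 in this assay is 5000 nM, within a range of 1000 nM to 25000 nM.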

Compound 4, half-maximal inhibitory concentration: 600 nM
Beside the measured number, compound 4's estimate is 8.3-fold (0.92 log units) above it; the whole stated range lies above it.
By their numbers in this assay, from the lowest: compound 1; then compound 4; then compound 2; then compound 3.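

In this assay, among the compounds shown here, this position responds strongly to the ring it carries: 3-fluorophenyl in place of 4-chlorophenyl gives a 33-fold lower number from compound 3 to compound 4 (1.52 log units; beyond the scatter), the largest of the steps so far, so two halogen-bearing phenyl rings need not behave alike here. Set against 4-methoxyphenyl, the same 3-fluorophenyl gives a 5.0-fold lower number from compound 2 to compound 4 (0.70 log units; beyond the scatter), which means that among these three substituted rings, 3-fluorophenyl gives the lowest number and the two rings named with a 4-substituent give higher ones. Nothing presented here gives a measured reason for these differences.

The step from 4-chlorophenyl to 3-fluorophenyl changes both the halogen and where it sits on the ring, so these compounds cannot show how much of the drop belongs to each change; 4-fluorophenyl or 3-chlorophenyl at this place would separate the two. Also open is how other groups on this ring, such as 3-methoxyphenyl or a phenyl ring carrying an amine, would fit among these numbers, and whether the 3-fluorophenyl result would hold with a longer chain on the same saturated carbon.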